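From a Branched Chain Back to an Aromatic Ring

The source may report more compounds than this note shows. Statements on the series, on what has been measured and on what is new or still open speak of the compounds shown alone.

Compound 1, `COc1cc(N)c(Cl)cc1NC(=O)C1CCN(Cc2ccc(F)cc2)CC1`: 0.6 mg/kg
Compound 2, `COc1cc(N)c(Cl)cc1NC(=O)C1CCN(Cc2cccc(C)c2)CC1`: 2.4 mg/kg
Compound 3, `CCC(CC)CN1CCC(C(=O)Nc2cc(Cl)c(N)cc2OC)CC1`: > 10 mg/kg

These three share one core and differ only in the group on a saturated chain carbon bound to an amine nitrogen in a ring. In a functional assay on the whole organism for antagonist activity, with Mus musculus as the target (a higher number here means that more compound is needed for the effect, a lower number that less compound is needed), compound 3 sits at a limit of the assay, (the limit of > 10 mg/kg in this assay, at which 1 of the 3 values shown sits), so its true value is not known. Compound 4, `COc1cc(N)c(Cl)cc1NC(=O)C1CCN(Cc2cccc(Cl)c2)CC1`, differs from compound 3 by 3-chlorophenyl in place of pentan-3-yl on a saturated chain carbon bound to an amine nitrogen in a ring. The measured steps in this assay that bear on this change run the other way: an at least 4.1-fold higher number from compound 2 to compound 3 (0.61 log units; beyond the scatter) and an at least 16-fold higher number from compound 1 to compound 3 (1.22 log units; beyond the scatter). Both go from an aromatic ring to the branched chain and both raise the number beyond the scatter, so returning to an aromatic ring is expected to lower it. Compound 4 is therefore expected to give 2 mg/kg, between 0.7 mg/kg and 6 mg/kg. That would be an estimated step of an at least 5.0-fold lower number from compound 3 to compound 4 (0.69 log units; beyond the scatter).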

Compound 4, dose for half-maximal effect: > 4 mg/kg
Compound 4: a limit, no number (the forecaster's own chance of this, stated with the estimate: 10%); middle value at least 2.0-fold (0.30 log units) from the limit.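

In this assay compound 4 gives a limit, not a number: the limit of > 4 mg/kg in this assay, at which 1 of the 4 values shown sits.

The step between the two limits cannot be read, so nothing shows that 3-chlorophenyl improves on the branched chain. An aromatic ring alone therefore does not secure a low number at this place: there is an at least 6.6-fold higher number from compound 1 to compound 4 (0.82 log units; beyond the scatter), and an at least 1.6-fold higher number from compound 2 to compound 4 (0.22 log units; that floor lies within the scatter), so the swap of chloro for methyl may matter little or much.

From the compounds shown here alone, the true value of compound 4 stays open. Also open, going by these compounds, is whether the low number of compound 1 depends on the fluoro group or on where it sits, which 3-fluorophenyl or 4-chlorophenyl on the same carbon would separate.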